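A Cyclohexyl Step in a Chemokine Receptor Antagonist Series

The source may hold more compounds than are shown below. What is called first, only, known or untested is meant among the compounds shown, and "the series" means these compounds.

Compound 1 `COc1ccc2nccc(C3CN(C4CCN(Cc5cc6ccccc6n5C)CC4)C(=O)O3)c2c1`: 3160 nM
Compound 2 `CCCCCCN1CCC(N2CC(c3ccnc4ccc(OC)cc34)OC2=O)CC1`: 501 nM

In an in vitro functional assay on RBL cells for antagonist activity at C-C chemokine receptor type 8 (Homo sapiens), read by FLIPR and calcium flux (a higher number here means a weaker inhibitor, a lower number a stronger inhibitor), compound 2 stands with the lowest of the two numbers; the step of a 6.3-fold lower number from compound 1 to compound 2 (0.80 log units; beyond the scatter) is modest and beyond the scatter. Compound 3 `COc1ccc2nccc(C3CN(C4CCN(CC5CCCCC5)CC4)C(=O)O3)c2c1` carries cyclohexyl in place of pentyl on a saturated chain carbon bound to an amine nitrogen in a ring. Within the data shown here, only the step from compound 1 to compound 2 bears on this change, and it concerns a different group leaving the same place, so it gives little guidance. Among the measured compounds shown here, with no direct precedent, compound 3 is estimated to sit close to compound 2 in this assay, the step of a 1.0-fold lower number from compound 2 to compound 3 (0.00 log units; within the scatter) expected to fall within the scatter, at 500 nM with a range of 200 nM to 1300 nM.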

Compound 3, half-maximal inhibitory concentration: 7940 nM
Compound 3: middle estimate off by 16-fold (1.20 log units), on the low side; the measured number lies above the stated range.
By their numbers in this assay, from the lowest: compound 2; then compound 1; then compound 3.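

In this assay, the position on a saturated chain carbon bound to an amine nitrogen in a ring separates two groups made only of carbon: cyclohexyl in place of pentyl brings a 16-fold higher number from compound 2 to compound 3 (1.20 log units; beyond the scatter) with no hydrogen-bond donor or acceptor on either side. Cyclohexyl also compares poorly with 1-methyl-1H-indol-2-yl, giving a 2.5-fold higher number from compound 1 to compound 3 (0.40 log units; beyond the scatter) and leaving compound 2, with its open chain, lowest of these three. On these data alone, whether a longer chain such as heptyl would go lower than compound 2 remains open, as does whether cyclopentyl would behave like cyclohexyl. No evidence accounts for either step.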